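Replacing the imidazolyl of compound 2 by anilino

The compounds below may be only part of what the source reports. "The series", "measured", "known", "first", "only" and "open" are said of these compounds alone.

Measured compounds so far:
compound 1 `Cc1cc(Sc2ccncc2)c(S(C)(=O)=O)cc1C(=O)N=C(N)N`: 13 nM
compound 2 `Cc1cn(-c2cc(C)c(C(=O)N=C(N)N)cc2S(C)(=O)=O)cn1`: 28 nM

Among the compounds with values here, compound 2 gives the highest of the two numbers in a functional assay for inhibition of sodium/hydrogen exchanger (Oryctolagus cuniculus); on this read-out lower numbers stand for stronger inhibition and higher numbers for weaker inhibition; its nearest neighbour is compound 1, and the single measured step, a 2.2-fold higher number from compound 1 to compound 2 (0.33 log units; beyond the scatter), lies beyond the scatter.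

Compound 3 `Cc1cc(Nc2ccccc2)c(S(C)(=O)=O)cc1C(=O)N=C(N)N` is not yet measured. It differs from compound 2 by anilino in place of 4-methyl-1H-imidazol-1-yl on an aromatic carbon. Within the data shown here, the only step that bears on this change is a 2.2-fold higher number from compound 1 to compound 2 (0.33 log units; beyond the scatter): there, a six-membered aromatic ring carried through a single linking atom stood against the five-membered ring, and compound 1 gave 13 nM. The anilino group of compound 3 is again a six-membered ring on a single linking atom. A modest step back toward the number of compound 1 is therefore expected, a 1.9-fold lower number from compound 2 to compound 3 (0.27 log units; within the scatter). For compound 3 the estimate in this assay is 15 nM, with a range from 5 nM to 50 nM.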

Compound 3, half-maximal inhibitory concentration: 21 nM
Compound 3: middle estimate off by 1.4-fold (0.15 log units), on the low side, within the range that was stated.
By their numbers in this assay, from the lowest: compounds 1, 3 and 2 (each within the scatter of the next, the first and the last beyond it).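

In this assay the anilino group gives a 1.3-fold lower number from compound 2 to compound 3 (0.12 log units; within the scatter) and, against the (pyridin-4-yl)sulfanyl group, a 1.6-fold higher number from compound 1 to compound 3 (0.21 log units; within the scatter). Anilino therefore cannot be told apart from either group at this aromatic carbon ortho to the methylsulfonyl group, even though compound 1 and compound 2 differ beyond the scatter, and a six-membered aromatic ring of carbon only on a nitrogen link is accepted here without a ring nitrogen. Nothing available accounts for these small differences.

Still open, from the compounds shown here alone, is whether the hydrogen on the anilino nitrogen matters, which a phenoxy or an N-methylanilino group at this carbon would test. Also open, going by these compounds, is how the position responds to a non-aromatic group such as piperidin-1-yl, or to a chloro or methoxy group on the anilino ring.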